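The source may hold more compounds than are shown below. What is called first, only, known or untested is meant among the compounds shown, and "the series" means these compounds.

Measured in a functional assay on PC-3 cells (Homo sapiens) for inhibition, read by MTT assay, with stated times of 18 h and 4 h; on this read-out higher numbers stand for weaker inhibition and lower numbers for stronger inhibition:
- compound 1 `CCCCCCCCCCOP(=O)(O)OCCSC(=S)N1CCN(C)CC1`: 80000 nM
- compound 2 `CCCCCCCCOP(=O)(O)OCCSC(=S)N1CCCCCC1`: 56800 nM
- compound 3 `CCCCCCOP(=O)(O)OCCSC(=S)N1CCCCCC1`: > 100000 nM (a limit, not a number)

Compound 3 has no exact value on this scale and stands only at the limit of > 100000 nM in this assay, at which 1 of the 3 values shown sits. Compound 4 `CCCCCCOP(=O)(O)OCCSC(=S)N1CCN(C)CC1` carries 4-methylpiperazin-1-yl in place of azepan-1-yl on a thiocarbonyl carbon. Within the data shown here, no measured step isolates this swap. Among the measured compounds shown here, the one measured step, an at least 1.7-fold higher number from compound 2 to compound 3 (0.24 log units; that floor lies within the scatter), alters the chain instead. Compound 1 and compound 2 differ in both chain and ring, and their values lie within the scatter of each other. No step beyond the scatter is therefore expected, and a limit is again likely. The expected step is a step that the limit leaves unreadable from compound 3 to compound 4. The estimate for compound 4 is 130000 nM, with an expected range of 70000 nM to 250000 nM.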

Compound 4, half-maximal inhibitory concentration: > 100000 nM
Compound 4 ended at the assay's limit; the forecaster's own chance of this, stated with the estimate: 70%; the middle value lies beyond the limit too.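

In this assay compound 4 gives > 100000 nM, which is a limit and not a number. The step for 4-methylpiperazin-1-yl in place of azepan-1-yl on a thiocarbonyl carbon cannot be read, because compound 3 and compound 4 both stop at that ceiling: the limit of > 100000 nM in this assay, at which 2 of the 4 values shown sit. With 4-methylpiperazin-1-yl kept, hydrogen in place of butyl on the chain gives an at least 1.2-fold higher number from compound 1 to compound 4 (0.09 log units; that floor lies within the scatter), so only a floor is known for this chain change.

Still open, as far as these compounds go, is whether a dodecyl chain on either ring would bring values into the readable range. Only such values could size the ring swap.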